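The source may report more compounds than this note shows. Statements on the series, on what has been measured and on what is new or still open speak of the compounds shown alone.

Three analogues share a core in which a sulfonamide nitrogen carries a substituted phenyl ring: compound 1 `Cc1cccc(NS(=O)(=O)c2ccc(N3CCNC3=O)cc2)c1`, compound 2 `CCc1ccc(NS(=O)(=O)c2ccc(N3CCNC3=O)cc2)cc1` and compound 3 `Cc1ccc(NS(=O)(=O)c2ccc(N3CCNC3=O)cc2)c(C)c1`. In a functional assay on HT-29 cells (Homo sapiens) for antiproliferative activity, read by sulforhodamine B assay, with a stated time of 48 h (on this read-out higher numbers stand for weaker inhibition and lower numbers for stronger inhibition), compound 1 gives 110 nM, compound 3 gives 180 nM, and compound 2 gives 660 nM, the highest of the three numbers. The steps to it are a 6.0-fold higher number from compound 1 to compound 2 (0.78 log units; beyond the scatter) and, back down, a 3.7-fold lower number from compound 2 to compound 3 (0.56 log units; beyond the scatter), while a 1.6-fold higher number from compound 1 to compound 3 (0.21 log units; within the scatter) stays within the scatter.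

Compound 4 `CCCCCCOc1ccc(NS(=O)(=O)c2ccc(N3CCNC3=O)cc2)cc1` departs from compound 2 by hexyloxy in place of ethyl on an aromatic carbon. Going by the values given here, no measured pair exchanges one group for another at this same place, so the bearing steps are only indirect: they show that the phenyl pattern of compound 2 sits at the weak end, and nothing shows how a hexyloxy group there behaves. Compound 4 is therefore expected to remain near compound 2, with a step of a 1.4-fold higher number from compound 2 to compound 4 (0.13 log units; within the scatter) that is uncertain in direction. The value of compound 4 in this assay is estimated at 900 nM, within a range from 250 nM to 3500 nM.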

Compound 4, half-maximal inhibitory concentration: > 1000 nM
Compound 4: only a limit was reported (the forecaster's own chance of this, stated with the estimate: 15%); middle value at least 1.1-fold (0.04 log units) away from the limit.
By their numbers in this assay, from the lowest: compounds 1 and 3 (each within the scatter of the next); then compound 2. At a limit, above all of these: compound 4.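

The reading for compound 4 in this assay is a limit and not a number: the limit of > 1000 nM in this assay, at which 1 of the 4 values shown sits. With hexyloxy in place of ethyl on the aromatic carbon para to a large group, the step is an at least 1.5-fold higher number from compound 2 to compound 4 (0.18 log units; that floor lies within the scatter), so the longer, oxygen-bearing group does not bring the number down from that of compound 2, though the floor alone does not establish a real loss. Going by these compounds alone, the earlier compounds carried only small alkyl groups on the phenyl ring, and this result is the first reading of a chain with an oxygen there.

Because oxygen and chain length enter together, the compounds shown leave open which of them matters, a question that a methoxy group or a plain hexyl chain at this place would address. On these data alone, how an amine or a carboxylic acid would behave there also remains open.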